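A few compounds are considered here, and "the series" means these few. Any claim that something is new, unique, unknown or untested is made for them only; others in the source may bear on it.

The measured compounds:

Compound 1, `CC(C)C(NC(=O)NO)C(=O)NC1CCCC1`: in a functional assay on MCF7 cells (Homo sapiens) for inhibition (on this read-out lower numbers stand for stronger inhibition and higher numbers for weaker inhibition), compound 1 reached only the limit of the assay, > 100000 nM, and so gives no number.
Compound 2, `CC(C)C(NC(=O)n1nnc2ccccc21)C(=O)NC1CCCC1`: in this assay compound 2 gives 79300 nM.
Compound 3, `CCC(C)C(NC(=O)n1nnc2ccccc21)C(=O)NC1CCCC1`: in this assay compound 3 gives 63700 nM.

Compound 1 and compound 2 share the right-hand part of the molecule but carry different cores; how the two cores differ is not broken down here. Compound 2 and compound 3 share a core and differ in one place, (methyl in place of hydrogen on a saturated chain carbon, three bonds along the chain from an amide-type nitrogen and a carbonyl carbon); this change gave a 1.2-fold lower number from compound 2 to compound 3 (0.10 log units; within the scatter).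

The unmeasured compound 4, `CCC(C)C(NC(=O)NO)C(=O)NC1CCCC1`, carries the core of compound 1 with the same change applied, (methyl in place of hydrogen on a saturated chain carbon, three bonds along the chain from an amide-type nitrogen and a carbonyl carbon). Beside the step from compound 2 to compound 3, the step from compound 1 to compound 4 is expected to be a number no higher from compound 1 to compound 4 (the limit leaves the size open). Going by the values given here, this rests on two things: compound 1 sits at the limit of > 100000 nM in this assay, at which 1 of the 3 values shown sits, and the one measured example of this change, a 1.2-fold lower number from compound 2 to compound 3 (0.10 log units; within the scatter), moved the value only a little. Compound 4 is therefore expected to give about 100000 nM in this assay, most likely again as a limit rather than a number.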

Compound 4, half-maximal inhibitory concentration: > 100000 nM
Compound 4: only a limit was reported; the forecaster's own chance of this, stated with the estimate: 80%; the middle value sits exactly at the limit.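

Compound 4, like compound 1, is reported only as a limit and not as a number, so no step from compound 1 to compound 4 can be read: the limit of > 100000 nM in this assay, at which 2 of the 4 values shown sit.

The compounds shown leave open what the real values of compound 1 and compound 4 are, and so whether methyl in place of hydrogen changes anything on this core.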